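Lengthening the ester chain from propyl to tert-butyl

The source may report more compounds than this note shows. Statements on the series, on what has been measured and on what is new or still open speak of the compounds shown alone.

Of the compounds shown here, two sharing one core have been tested in an assay on membranes from HEK293 cells for displacement of a labelled ligand from adenosine receptor A2b (Homo sapiens), read by scintillation counting, with a stated time of 30 min, tested at 1 uM; on this read-out higher numbers stand for more inhibition at the one concentration tested (going by the name of the read-out) and lower numbers for less inhibition. Compound 1 `COC(=O)C1=C(C)NC(=S)NC1c1cccs1` carries a methyl on the oxygen next to the carbonyl group, and in this assay compound 1 gives 10%. Compound 2 `CCCOC(=O)C1=C(C)NC(=S)NC1c1cccs1` carries a propyl there, and in this assay compound 2 gives 3%, the smaller of the two numbers on paper, although the step of a number 7 percentage points lower from compound 1 to compound 2 (within the scatter) is within the scatter, so the two compounds cannot be ranked against each other. Compound 3 `CC1=C(C(=O)OC(C)(C)C)C(c2cccs2)NC(=S)N1` differs from compound 2 by tert-butyl in place of propyl on an oxygen next to a carbonyl group. Among the compounds with values here, the single step on record, a number 7 percentage points lower from compound 1 to compound 2 (within the scatter), already enlarged this chain and left the number within the scatter; both measured values are small. With nothing else to point to, the expected step of a number 1 percentage points higher from compound 2 to compound 3 (within the scatter) is none beyond the scatter. Compound 3 is therefore estimated at 4%, with a range from -8% to 16%.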

Compound 3, a percentage reported as inhibition, at one concentration (the size of the read-out at that concentration, not a potency): 26%
For compound 3 the middle estimate is 22 percentage points below the measured one, outside the stated range (above it).
By their numbers in this assay, from the lowest: compounds 2 and 1 (each within the scatter of the next); then compound 3.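

In this assay, this position, on an oxygen next to a carbonyl group, turns out to respond to the group it carries: tert-butyl in place of propyl gives a number 23 percentage points higher from compound 2 to compound 3 (beyond the scatter), and tert-butyl in place of methyl gives a number 16 percentage points higher from compound 1 to compound 3 (beyond the scatter). Methyl and propyl could not be told apart, so tert-butyl is the first group here to move the number beyond the scatter, though both steps are modest and come from a single concentration, which says nothing directly about potency. No measurement on hand explains why this group stands apart from the other two.

From the compounds shown here alone, it remains open whether tert-butyl is unique at this place or whether isopropyl or a longer chain such as butyl would give a similar number. Going by these compounds, how a carboxylic acid or an amide in place of the ester would behave is also open.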